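The source may hold more compounds than are shown below. What is called first, only, known or untested is meant among the compounds shown, and "the series" means these compounds.

Measured compounds:
Compound 1, `Cc1c(O)c(=O)ccn1CC(=O)N/N=C1\C(=O)N(CC(=O)Nc2ccc(Cl)cc2)c2ccccc21`: 28300 nM
Compound 2, `Cc1c(O)c(=O)ccn1CC(=O)N/N=C1\C(=O)N(CC(=O)Nc2ccccc2Cl)c2ccccc21`: > 100000 nM

In a functional assay on A549 cells (Homo sapiens) for cytotoxicity, read by MTT assay, with a stated time of 48 h (on this read-out higher numbers stand for an effect only at larger amounts of compound and lower numbers for an effect already at smaller amounts), compound 1 gives 28300 nM. For compound 2 the assay reports only a limit, > 100000 nM, and no number. Going by the values given here, the one measured step, an at least 3.5-fold higher number from compound 1 to compound 2 (0.54 log units; beyond the scatter), is therefore read against that limit (the limit of > 100000 nM in this assay, at which 1 of the 2 values shown sits). Compound 3, `Cc1c(O)c(=O)ccn1CC(=O)N/N=C1\C(=O)N(CC(=O)Nc2ccc(Cl)cc2Cl)c2ccccc21`, differs from compound 2 by chloro in place of hydrogen on an aromatic carbon. Among the compounds with values here, only the step from compound 1 to compound 2 bears on this change, and it ran the other way: the 4-chlorophenyl of compound 1 gave a lower number in this assay than the 2-chlorophenyl of compound 2 by an at least 3.5-fold higher number from compound 1 to compound 2 (0.54 log units; beyond the scatter). Putting a chloro at that place again may bring compound 3 back toward compound 1. With compound 2 known only as a limit (the limit of > 100000 nM in this assay, at which 1 of the 2 values shown sits), the expected step for compound 3 is an at least 2.5-fold lower number from compound 2 to compound 3 (0.39 log units; beyond the scatter), though its size is uncertain. Compound 3 is estimated at 40000 nM, within 12000 nM to 150000 nM, in this assay.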

Compound 3, half-maximal effective concentration: 61500 nM
Estimate against measurement, compound 3: 1.5-fold (0.19 log units) below; the measured number falls inside the stated range.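

In this assay, compound 3 carries the second chloro on the 2-chlorophenyl, para to a large group, which gives an at least 1.6-fold lower number from compound 2 to compound 3 (0.21 log units; that floor lies within the scatter). Compound 2 is known only as a limit, so the true size of this step remains open: the limit of > 100000 nM in this assay, at which 1 of the 3 values shown sits.

Read from the other side, the 2,4-dichlorophenyl against the 4-chlorophenyl gives a 2.2-fold higher number from compound 1 to compound 3 (0.34 log units; beyond the scatter), so the chloro of the 2-chlorophenyl still goes with a higher number when the other chloro is present, and compound 1 keeps the lowest number of the three.

The compounds shown leave open whether a fluoro, methoxy or nitrile at these places would follow the chloro, and how an unsubstituted phenyl compares. They also do not say how an amine or a carboxylic acid on this ring would read.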